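Working notes: bromo in place of chloro

The compounds below may be only part of what the source reports. "The series", "measured", "known", "first", "only" and "open" are said of these compounds alone.

In a functional assay on C8166 cells (Homo sapiens) for cytotoxicity, read by MTT assay (a higher number here means that more compound is tolerated, a lower number that less compound is tolerated), compound 1 `Cc1cc(S(N)(=O)=O)ccc1NC(=O)COc1ccc(Cl)cc1NC(=O)c1ccccc1C` gives 67300 nM, compound 2 `Cc1cc(S(N)(=O)=O)ccc1NC(=O)COc1ccc(Cl)cc1NC(=O)c1cccc(Cl)c1` gives 59700 nM and compound 3 `Cc1cc(S(N)(=O)=O)ccc1NC(=O)COc1ccc(Cl)cc1NC(=O)c1cc(Cl)cc(Br)c1` gives 114000 nM. Compound 3 stands within the scatter of both others. Compound 4 `Cc1cc(S(N)(=O)=O)ccc1NC(=O)COc1ccc(Cl)cc1NC(=O)c1cc(Br)cc(Br)c1` carries 3,5-dibromophenyl in place of 3-bromo-5-chlorophenyl: bromo in place of chloro on an aromatic carbon, (bromo in place of chloro on an aromatic carbon). The closest evidence is bromo in place of hydrogen, a 1.9-fold higher number from compound 2 to compound 3 (0.28 log units; within the scatter). The wider swaps on the carbonyl carbon, a 1.1-fold lower number from compound 1 to compound 2 (0.05 log units; within the scatter) and a 1.7-fold higher number from compound 1 to compound 3 (0.23 log units; within the scatter), also stay within the scatter. No step beyond the scatter is therefore expected in this assay. The expected step is a 1.1-fold lower number from compound 3 to compound 4 (0.04 log units; within the scatter). Compound 4 is estimated at 105000 nM, with an expected range of 60000 nM to 180000 nM.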

Compound 4, half-maximal cytotoxic concentration: 89700 nM
Estimate against measurement, compound 4: 1.2-fold (0.07 log units) above; measured number inside the range.
By their numbers in this assay, from the lowest: compounds 2, 1, 4 and 3 (each within the scatter of the next).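

In this assay, bromo in place of chloro on this aromatic carbon, meta to a bromo group, gives a 1.3-fold lower number from compound 3 to compound 4 (0.10 log units; within the scatter) and stays within the scatter. The 3,5-dibromophenyl group likewise shows no step beyond the scatter against the other groups on the carbonyl carbon, with a 1.5-fold higher number from compound 2 to compound 4 (0.18 log units; within the scatter) and a 1.3-fold higher number from compound 1 to compound 4 (0.12 log units; within the scatter) in the same assay. The compounds shown leave open whether an amine or a carboxylic acid on this aromatic carbon would give a step beyond the scatter in this assay. No measurement at hand offers an explanation for these steps.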